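The source may report more compounds than this note shows. Statements on the series, on what has been measured and on what is new or still open speak of the compounds shown alone.

Working notes on the series. Compound 1 `O=C(O)c1ccccc1COc1ccc(OCCOCCNC2CCCC2)cc1` is the reference point for this step. In a functional assay on SK-OV-3 cells (Homo sapiens) for inhibition, read by CCK-8 assay, with a stated time of 70 h (a lower number here means a stronger inhibitor, a higher number a weaker inhibitor), compound 1 gives > 100000 nM, which is a limit of the assay rather than a number, so compound 1 stands only at the edge of what the assay reports (the limit of > 100000 nM in this assay, at which 1 of the 2 values shown sits). For the measured compounds named here, the other measured member is compound 2 `c1ccc(COc2ccc(OCCOCCNC3CC3)cc2)cc1`, which differs from compound 1 in more than one place, so no single step joins the two. In this assay, going by the values given here, compound 2 gives 47200 nM, the one actual number in the set so far.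

The change considered next leads to compound 3 `O=C(O)c1ccc(COc2ccc(OCCOCCNC3CCCC3)cc2)cc1`: 4-carboxyphenyl in place of 2-carboxyphenyl on a saturated chain carbon bound to an oxygen on an aromatic ring. Among the compounds with values here, no measured step of this kind exists among the compounds so far, so the size of the step in this assay cannot be read from data; the working expectation is a step of no more than the usual scatter, without a clear direction, and a fair chance that the assay again returns only a limit. Compound 3 is expected at 100000 nM, within 30000 nM to 400000 nM. The step that this estimate implies is a number no higher from compound 1 to compound 3 (the limit leaves the size open).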

Compound 3, half-maximal inhibitory concentration: > 100000 nM
Compound 3 was reported as a limit; the forecaster's own chance of this, stated with the estimate: 60%; the middle value sits exactly at the limit.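

Compound 1 and compound 3 both stand only at a limit in this assay, so no step between them can be read: the limit of > 100000 nM in this assay, at which 2 of the 3 values shown sit.

The compounds shown leave open whether 4-carboxyphenyl in place of 2-carboxyphenyl makes any difference in this assay, and what actual numbers compound 1 and compound 3 would give.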